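A few compounds are considered here, and "the series" means these few. Any claim that something is new, unique, unknown or untested is made for them only; others in the source may bear on it.

Of the compounds shown here, three have so far been tested in a functional assay on A-375 cells (Homo sapiens) for antiproliferative activity, read by CCK-8 assay, with a stated time of 72 h, tested at 8 uM; a lower number here means a weaker effect, a higher number a stronger effect of the compound at the concentration tested. Compound 1 `Nc1ccccc1NC(=O)c1ccc(CSC(=S)N2CCN(c3ccccc3)CC2)cc1` gives 88.6%, the highest of the three numbers, though only within the scatter: compound 3 `CN(C(=S)SCc1ccc(C(=O)Nc2ccccc2N)cc1)c1cccnc1` gives 87.7% and compound 2 `Nc1ccccc1NC(=O)c1ccc(CSC(=S)N2CCc3ccccc32)cc1` gives 85.4%. Going by the values given here, the single measured step, a number 2.3 percentage points higher from compound 2 to compound 3 (within the scatter), shows that swapping the group on the thiocarbonyl carbon left this assay essentially unchanged. Compound 4 `COc1ccc(N2CCN(C(=S)SCc3ccc(C(=O)Nc4ccccc4N)cc3)CC2)cc1` differs from compound 1 by methoxy in place of hydrogen on an aromatic carbon, which turns the phenyl into 4-methoxyphenyl. Among the compounds with values here, no measured step touches this part of the molecule, so the flat response seen so far is the only guide, and compound 4 is expected to show a number 1.6 percentage points lower from compound 1 to compound 4 (within the scatter), nothing beyond the scatter. Compound 4 is estimated at 87%, within a range from 77% to 94%.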

Compound 4, a percentage reported as inhibition, at one concentration (the size of the read-out at that concentration, not a potency): 35.9%
Estimate against measurement, compound 4: 51.1 percentage points above, outside the stated range (below it).
By their numbers in this assay, from the lowest: compound 4; then compounds 2, 3 and 1 (each within the scatter of the next).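

Going by these compounds alone, the one earlier step, at the thiocarbonyl carbon, stayed within the scatter, but this position on the phenyl ring is far from silent: in this assay, methoxy in place of hydrogen, para to a large group, gives a number 52.7 percentage points lower from compound 1 to compound 4 (beyond the scatter). So an addition of just 2 heavy atoms, with no ring and no net charge, can nearly undo the effect at the concentration tested. Nothing at hand gives a cause for this drop. Going by these compounds, it remains open whether the loss is specific to methoxy or extends to other groups on this carbon, such as a hydroxyl, a methyl or a fluorine.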